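Replacing 4-fluorophenyl with pyridin-2-yl at the assay limit

The source may report more compounds than this note shows. Statements on the series, on what has been measured and on what is new or still open speak of the compounds shown alone.

Compound 1 `S=c1oc(-c2ccc3c(c2)OCCO3)nn1CN1CCN(c2ccccc2)CC1` gives > 50000 nM in a functional assay on BGC-823 cells (Homo sapiens) for antiproliferative activity, read by MTT assay, with a stated time of 48 h (on this read-out lower numbers stand for stronger inhibition and higher numbers for weaker inhibition), and this is a limit of the assay, not a number. Compound 2 `Fc1ccc(N2CCN(Cn3nc(-c4ccc5c(c4)OCCO5)oc3=S)CC2)cc1` gives > 50000 nM in this assay and this too is only a limit. Compound 2 therefore stands at the limit of > 50000 nM in this assay, at which 2 of the 2 values shown sit, and has no number of its own.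

The next structure is compound 3 `S=c1oc(-c2ccc3c(c2)OCCO3)nn1CN1CCN(c2ccccn2)CC1`, which carries pyridin-2-yl in place of 4-fluorophenyl on an amine nitrogen in a ring, and the counted change is pyridin-2-yl in place of 4-fluorophenyl on an amine nitrogen in a ring with the rest of the molecule untouched. Within the data shown here, the one measured step that bears on this is a step that the two limits leave unreadable from compound 1 to compound 2 with fluoro in place of hydrogen on an aromatic carbon, and it offers no size to carry over. No direction can be argued for this assay from so little, and another reading at the limit is the likeliest outcome, though a number close to it remains possible. The expected step is a number no higher from compound 2 to compound 3 (the limit leaves the size open) and none beyond the scatter is anticipated. For compound 3 the estimated value is 50000 nM with an expected range from 15000 nM to 100000 nM on repeated measurement.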

Compound 3, half-maximal inhibitory concentration: 25900 nM
The estimate for compound 3 lay 1.9-fold (0.29 log units) above the measured number; low and high end bracket the measured number.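

In this assay, among these compounds, compound 3 gives 25900 nM, the only true number among the three values shown, so this position on the amine nitrogen in a ring can now give a readable result. Pyridin-2-yl in place of 4-fluorophenyl gives an at least 1.9-fold lower number from compound 2 to compound 3 (0.28 log units; that floor lies within the scatter), and pyridin-2-yl in place of phenyl gives an at least 1.9-fold lower number from compound 1 to compound 3 (0.28 log units; that floor lies within the scatter); both sizes are floors only, so the real steps may be larger, but these floors alone do not establish a real gain. Compound 1 and compound 2 each stay at a limit of the assay, not a number: the limit of > 50000 nM in this assay, at which 2 of the 3 values shown sit.

The compounds shown leave open whether the ring nitrogen of pyridin-2-yl is what matters, and a pyridin-4-yl or pyrimidin-2-yl group on the same amine nitrogen would test that directly. They also leave open whether an aromatic ring is needed at this position at all, which a simple methyl or a cyclohexyl group in its place could begin to answer.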